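The source may report more compounds than this note shows. Statements on the series, on what has been measured and on what is new or still open speak of the compounds shown alone.

Compound 1, `CCCCCCCCCO[C@@H]1[C@@H](N)[C@@H](O[C@H]2[C@H](O)[C@@H](O)[C@H](N)C[C@@H]2N)O[C@H](CN)[C@H]1OCCCCCCCCC`, gives 82.7% in a toxicity assay on the whole organism (J774 cells) for cytotoxicity, with Mus musculus as the target, read by MTT assay, with a stated time of 24 h, tested at 10 uM; a higher number here means a weaker effect of the compound at the concentration tested, a lower number a stronger effect.
Compound 2, `CCCCCCCCCO[C@@H]1[C@@H](N)[C@@H](OC[C@H](O)CN=[N+]=[N-])O[C@H](CN)[C@H]1OCCCCCCCCC`, gives 62.2%.
Compound 3, `CCCCCCCCCO[C@@H]1[C@@H](N)[C@@H](OCC(O)CNCCN)O[C@H](CN)[C@H]1OCCCCCCCCC`, gives 87.5%.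

On these numbers compound 3 stands highest of the three: its nearest neighbour is compound 1, within the scatter, and its furthest is compound 2, beyond the scatter. Compound 4, `C=CCO[C@H]1O[C@H](CN)[C@@H](OCCCCCCCCC)[C@H](OCCCCCCCCC)[C@H]1N`, has not yet been measured. Against compound 3 the change is vinyl in place of 2-((2-aminoethyl)amino)-1-hydroxyethyl on a saturated chain carbon bound to an oxygen on a saturated carbon. Going by the values given here, two measured steps bear on this change. The step of a number 25.3 percentage points higher from compound 2 to compound 3 (beyond the scatter) shows that bringing in the 3-((2-aminoethyl)amino)-2-hydroxypropyl chain in place of the 3-azido-2-hydroxypropyl chain raised the number by a modest amount. The step of a number 20.5 percentage points lower from compound 1 to compound 2 (beyond the scatter) shows that trading 4,6-diamino-2,3-dihydroxycyclohexyl for 3-azido-2-hydroxypropyl lowered it by a modest amount. Compound 4 carries only the allyl group, with no donors or acceptors, so a modest drop is expected, around a number 19.5 percentage points lower from compound 3 to compound 4 (beyond the scatter) in this assay. Compound 4 is therefore estimated at 68%, within the range 48% to 86%.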

Compound 4, a percentage reported as activity, at one concentration (the size of the read-out at that concentration, not a potency): 91.4%
For compound 4 the middle estimate is 23.4 percentage points below the measured one; the whole stated range lies below it.
By their numbers in this assay, from the lowest: compound 2; then compounds 1, 3 and 4 (each within the scatter of the next).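

In this assay, the group on this oxygen can shrink all the way to allyl with no readable change: a number 3.9 percentage points higher from compound 3 to compound 4 (within the scatter) and a number 8.7 percentage points higher from compound 1 to compound 4 (within the scatter) both stay within the scatter. Allyl has no hydrogen-bond donors or acceptors, so among these compounds such groups on this chain are not needed to keep the number at this level, and the amine-bearing chain of compound 3 and the diaminodihydroxycyclohexyl group of compound 1 add nothing readable over it, while a number 29.2 percentage points higher from compound 2 to compound 4 (beyond the scatter) leaves compound 2, with its azido chain, as the only one set apart. Nothing available explains why that chain alone differs.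

Going by these compounds, it remains open whether a carboxylic acid on this oxygen would read like compound 4 or like compound 2. On these data alone, it is also open whether the azide itself sets compound 2 apart, which the same chain ending in a hydroxyl or a methoxy group could test.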